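Chloro to Methyl on a Fused Core: Solubility Outlook

This account rests on a few compounds, and the source may have more. Where it says the series, first, only, none or still open, it means among the compounds named here.

Compound 1, `CC(C)Nc1nc(NCc2ccco2)c2cccc(Cl)c2n1`: in a physicochemical assay for solubility, at pH 7.4 (a higher number here means a more soluble compound, a lower number a less soluble compound), compound 1 gives <= 5000 nM, which is a limit of the assay.
Compound 2, `CC(C)Nc1nc(NCc2ccco2)c2ccc(Cl)cc2n1`: in this assay compound 2 gives <= 20000 nM, also a limit of the assay.
Compound 3, `Cc1cccc2c(NCc3ccco3)nc(NC(C)C)nc12`: in this assay compound 3 gives <= 20000 nM, again a limit of the assay.

Compound 1 and compound 2 have the same atoms joined differently; the difference between the two cores is not broken down here. Compound 3 arises from compound 1 by methyl in place of chloro on an aromatic carbon, and the resulting step that the two limits leave unreadable from compound 1 to compound 3 cannot be sized, since both ends sit at limits. The evidence available is the limit of <= 20000 nM in this assay, at which 2 of the 3 values shown sit, and (the limit of <= 5000 nM in this assay, at which 1 of the 3 values shown sits).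

Compound 4, `Cc1ccc2c(NCc3ccco3)nc(NC(C)C)nc2c1`, has not been measured. It arises from compound 2 by methyl in place of chloro on an aromatic carbon, the same kind of change as from compound 1 to compound 3, though the place differs: ortho to a fused ring and meta to a fused ring in the first case, meta to a fused ring and para to a fused ring in the second.

The step expected from compound 2 to compound 4 is a step that the limit leaves unreadable from compound 2 to compound 4, an estimate resting on the unreadable step that the two limits leave unreadable from compound 1 to compound 3, which gives no basis for a sized change. Compound 4 is therefore expected to give 15000 nM in this assay, most likely as a limit again.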

Compound 4, solubility: <= 20000 nM
Compound 4: no number, only a limit (the forecaster's own chance of this, stated with the estimate: 65%); the middle value is on the limit's open side.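

In this assay compound 4 gives <= 20000 nM, which is a limit of the assay. Compound 2 also stands at a limit, so no size can be read for the step between compound 2 and compound 4. The compounds shown leave open what exact value each would give, and so whether methyl in place of chloro on an aromatic carbon shifts the result at all.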